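Cyclohexyl in Place of Cyclopropyl on the Alkyne

The source may hold more compounds than are shown below. What is called first, only, known or untested is meant among the compounds shown, and "the series" means these compounds.

Three compounds share one core and differ only in the group on the triple-bonded carbon. Compound 1 `CNC(=O)[C@@]12C[C@@H]1[C@@H](n1cnc3c(NC)nc(C#Cc4ccccc4F)nc31)[C@H](O)[C@@H]2O` gives 20% in an assay on CHO cells for displacement of a labelled ligand from adenosine receptor A1 (Homo sapiens), read by scintillation counting, with a stated time of 60 min, tested at 10 uM; a lower number here means less inhibition, a higher number more inhibition at the concentration tested (going by the name of the read-out). Compound 2 `CNC(=O)[C@@]12C[C@@H]1[C@@H](n1cnc3c(NC)nc(C#Cc4cccnc4)nc31)[C@H](O)[C@@H]2O` gives 16% in this assay, and a number 4 percentage points lower from compound 1 to compound 2 (within the scatter). Compound 3 `CNC(=O)[C@@]12C[C@@H]1[C@@H](n1cnc3c(NC)nc(C#CC4CC4)nc31)[C@H](O)[C@@H]2O` gives 38% and stands highest of the three numbers, as a number 18 percentage points higher from compound 1 to compound 3 (beyond the scatter) and a number 22 percentage points higher from compound 2 to compound 3 (beyond the scatter).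

Compound 4 `CNC(=O)[C@@]12C[C@@H]1[C@@H](n1cnc3c(NC)nc(C#CC4CCCCC4)nc31)[C@H](O)[C@@H]2O` has not yet been measured. It differs from compound 3 in one place: cyclohexyl in place of cyclopropyl on a triple-bonded carbon. The two steps that end at compound 3 both exchanged a 2-fluorophenyl or pyridin-3-yl group for cyclopropyl and were modest in size. Within the data shown here, no measured step compares two cycloalkyl rings of different size with each other, so the data give no direct guide for the present change. The step of a number 2 percentage points higher from compound 3 to compound 4 (within the scatter) is therefore expected to be small, in either direction, and probably within the scatter. Compound 4 is estimated at 40%, with a range from 20% to 60%.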

Compound 4, a percentage reported as inhibition, at one concentration (the size of the read-out at that concentration, not a potency): 15%
For compound 4 the middle estimate is 25 percentage points above the measured one; the measured number lies below the stated range.
By their numbers in this assay, from the lowest: compounds 4, 2 and 1 (each within the scatter of the next); then compound 3.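

In this assay, ring size on the triple-bonded carbon proves to matter: a number 23 percentage points lower from compound 3 to compound 4 (beyond the scatter), so cyclopropyl and cyclohexyl, although each is a non-aromatic ring of carbon only, are not interchangeable at this position. Compound 4 does not separate from the compounds carrying 2-fluorophenyl and pyridin-3-yl, with a number 1 percentage points lower from compound 2 to compound 4 (within the scatter) and a number 5 percentage points lower from compound 1 to compound 4 (within the scatter), so a non-aromatic carbon ring alone does not bring the higher number seen for compound 3. Nothing measured here explains the drop.

The compounds shown leave open whether cyclobutyl or cyclopentyl would read closer to cyclopropyl or to cyclohexyl, and so whether the change with ring size is gradual or abrupt. They also leave open how an open chain such as propyl, or a ring carrying an amine, would read at this position.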